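A few compounds are considered here, and "the series" means these few. Any claim that something is new, unique, unknown or untested is made for them only; others in the source may bear on it.

The study sets three compounds side by side in a functional assay on KB cells (Homo sapiens) for cytotoxicity, read by MTT assay, with a stated time of 3 days; on this read-out lower numbers stand for an effect already at smaller amounts and higher numbers for an effect only at larger amounts of compound. Compound 1 `CC(=O)OC(C)(C)C1CC/C(C)=C/CC/C(C)=C/CCC2=C[C@@H]1OC2=O` gives 0.72 ug/mL in this assay. Compound 2 `C=C(C)C1CC[C@@]2(C)CCC[C@@](C)(OC(C)=O)[C@@H]2C1` reaches only the limit of the measurement in this assay, > 50 ug/mL, and that is all its value states. Where compound 2 stands is thus described by the limit of > 50 ug/mL in this assay, at which 1 of the 2 values shown sits, one of the two values shown. Compound 3 `C=C(C)C1CC[C@@]2(C)CCC[C@@](C)(O)[C@@H]2C1` differs from compound 2 in one place: hydrogen in place of acetyl on an oxygen on a saturated carbon. Going by the values given here, no step between measured compounds is available to gauge what this change does in this assay. Compound 2 sits at the limit > 50 ug/mL. The step that the limit leaves unreadable from compound 2 to compound 3 is accordingly expected to be small, in no direction beyond the scatter. Compound 3 is expected to give 60 ug/mL in this assay, within a range from 20 ug/mL to 200 ug/mL, and it may well return only a limit again.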

Compound 3, concentration for half-maximal effect: > 50 ug/mL
Compound 3: no number, only a limit (the forecaster's own chance of this, stated with the estimate: 75%); the middle value is on the limit's open side.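

No step can be read from compound 2 to compound 3, because both return only a limit and no number: the limit of > 50 ug/mL in this assay, at which 2 of the 3 values shown sit. The compounds shown leave open whether acetoxy to hydroxy changes anything in this assay and how far either compound lies beyond that limit.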